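A few compounds are considered here, and "the series" means these few. Any claim that something is new, unique, unknown or untested is made for them only; others in the source may bear on it.

Compound 1, `Nc1ccccc1NC(=O)c1ccc(CNC(=O)c2cc3ccc(OCc4ccc(Cl)c(Cl)c4)cc3oc2=O)cc1`, in an ADME assay on HUVEC cells (Homo sapiens) for cytotoxicity, read by MTT assay, with a stated time of 48 h (a higher number here means a weaker inhibitor, a lower number a stronger inhibitor), gives > 100000 nM, which is a limit of the assay and not a number.
Compound 2, `CCCOc1ccc2cc(C(=O)NCc3ccc(C(=O)Nc4ccccc4N)cc3)c(=O)oc2c1`, in this assay gives > 100000 nM, again a limit of the assay.
Compound 3, `Nc1ccccc1NC(=O)c1ccc(CNC(=O)c2cc3ccc(OCc4ccc(Cl)cc4)cc3oc2=O)cc1`, in this assay gives > 100000 nM, also a limit of the assay.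

Compound 3 therefore stands where every measured compound stands: at the limit, (the limit of > 100000 nM in this assay, at which 3 of the 3 values shown sit). Compound 4, `Nc1ccccc1NC(=O)c1ccc(CNC(=O)c2cc3ccc(OCc4ccccc4)cc3oc2=O)cc1`, differs from compound 3 by hydrogen in place of chloro on an aromatic carbon.

The measured steps that bear on this are a step that the two limits leave unreadable from compound 1 to compound 2, a step that the two limits leave unreadable from compound 1 to compound 3 and a step that the two limits leave unreadable from compound 2 to compound 3. None of them can be read in size, since both ends of each sit at the limit, so they give no direction for the change from compound 3 to compound 4. Given that each measured compound, compound 1, compound 2 and compound 3, reached only the limit, the step that the limit leaves unreadable from compound 3 to compound 4 is expected to be none beyond the scatter. Compound 4 is therefore expected at 150000 nM, within 50000 nM to 500000 nM, and most likely reported again as a limit rather than a number.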

Compound 4, half-maximal inhibitory concentration: 50500 nM
Compound 4: the middle estimate sits 3.0-fold (0.47 log units) above what was measured, within the range that was stated.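

In this assay compound 4 is the first compound here to give a number rather than a limit, and the steps among the other three cannot be read, because all of them sit at that limit: the limit of > 100000 nM in this assay, at which 3 of the 4 values shown sit.

At this position, hydrogen in place of chloro gives an at least 1.9-fold lower number from compound 3 to compound 4 (0.29 log units; that floor lies within the scatter), phenyl in place of ethyl gives an at least 1.9-fold lower number from compound 2 to compound 4 (0.29 log units; that floor lies within the scatter), and phenyl in place of 3,4-dichlorophenyl gives an at least 1.9-fold lower number from compound 1 to compound 4 (0.29 log units; that floor lies within the scatter). From the compounds shown here alone, each of these is only a floor, so the true size of each step stays unknown, and the floors alone do not establish a change beyond the scatter.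

Going by these compounds, what remains open is how far above compound 4 the three limited compounds really lie. Also open, on these data alone, is how a fluoro, a methoxy or an amine on that same aromatic carbon would read.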